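The compounds below may be only part of what the source reports. "The series", "measured", "known", "first", "only" and "open" are said of these compounds alone.

Measured compounds:
compound 1 `CCCCOC(=O)Nc1ccc(S(=O)(=O)N2C[C@H](c3ccccc3)NC2=O)cc1CC` — 200 nM
compound 2 `CC1[C@H](c2ccccc2)NC(=O)N1S(=O)(=O)c1ccc(NC(=O)c2ccc([N+](=O)[O-])cc2)c(Cl)c1` — > 10000 nM

In a functional assay on A549 cells (Homo sapiens) for cytotoxicity, read by MTT assay (on this read-out lower numbers stand for stronger inhibition and higher numbers for weaker inhibition), compound 1 gives 200 nM. Compound 2 reaches only a limit of the assay, > 10000 nM. Compound 1 thus holds the only real number shown; the other value is the limit of > 10000 nM in this assay, at which 1 of the 2 values shown sits.

Compound 3 `CCCOC(=O)Nc1ccc(S(=O)(=O)N2C[C@H](c3ccccc3)NC2=O)cc1CC` differs from compound 1 by one small change: hydrogen in place of methyl on a saturated chain carbon, three bonds along the chain from an oxygen next to a carbonyl group. Cut one bond further out, this reads as butyl to propyl. Going by the values given here, no measured pair shows this step, and such a shortening of a chain end is expected to move the result little, staying within scatter. The estimated step is a 1.3-fold higher number from compound 1 to compound 3 (0.10 log units; within the scatter). Compound 3 is expected to give about 250 nM, within 100 nM to 700 nM.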

Compound 3, half-maximal inhibitory concentration: 60 nM
Compound 3: middle estimate off by 4.2-fold (0.62 log units), on the high side; the measured number lies below the stated range.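

In this assay the change from butyl to propyl gives a 3.3-fold lower number from compound 1 to compound 3 (0.52 log units; beyond the scatter) and so lies beyond the scatter. Going by these compounds alone, the chain is therefore sensitive to the loss of a single carbon, a modest but real effect that no earlier pair could show. Nothing shown explains why this small change has such an effect.

A single step sets no trend. On these data alone, whether an ethyl chain would continue this direction, or a pentyl chain would give a higher or lower number than butyl, remains open.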